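The source may hold more compounds than are shown below. What is called first, only, known or untested is meant among the compounds shown, and "the series" means these compounds.

The measured compounds are:
compound 1 `Cn1c(=O)c(=O)n(C2CCCC2)c2nc(N/N=C/c3ccc(Cl)cc3)ncc21`, which in a functional assay on A549 cells (Homo sapiens) for antiproliferative activity, read by MTT assay (a higher number here means a weaker inhibitor, a lower number a stronger inhibitor), gives 6890 nM;
compound 2 `Cn1c(=O)c(=O)n(C2CCCC2)c2nc(N/N=C/c3ccc(O)c(F)c3)ncc21`, which in this assay gives 97800 nM;
compound 3 `Cn1c(=O)c(=O)n(C2CCCC2)c2nc(N/N=C/c3cccs3)ncc21`, for which this assay reports only a limit, > 100000 nM, and no number.

Compound 3 thus stands at the limit of > 100000 nM in this assay, at which 1 of the 3 values shown sits, separated from compound 1 by an at least 14-fold higher number from compound 1 to compound 3 (1.16 log units; beyond the scatter), while an at least 1.0-fold higher number from compound 2 to compound 3 (0.00 log units; that floor lies within the scatter) stays within the scatter. Compound 4 `Cn1c(=O)c(=O)n(C2CCCC2)c2nc(N/N=C/c3ccccc3F)ncc21` differs from compound 3 by 2-fluorophenyl in place of thiophen-2-yl on a carbon with a double bond to nitrogen. The step bearing on this change is an at least 14-fold higher number from compound 1 to compound 3 (1.16 log units; beyond the scatter), which ran the other way when thiophen-2-yl entered for 4-chlorophenyl; a 14-fold higher number from compound 1 to compound 2 (1.15 log units; beyond the scatter) shows that a six-membered ring of another kind can also cost much. A return to a phenyl ring is therefore expected to lower the number, giving an at least 5.0-fold lower number from compound 3 to compound 4 (0.69 log units; beyond the scatter). Compound 4 is estimated at 20000 nM, within 5000 nM to 100000 nM.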

Compound 4, half-maximal inhibitory concentration: 31200 nM
The estimate for compound 4 lay 1.6-fold (0.19 log units) below the measured number; low and high end bracket the measured number.
By their numbers in this assay, from the lowest: compound 1; then compound 4; then compound 2. At a limit, above all of these: compound 3.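

A phenyl ring at this carbon does not by itself restore the level of compound 1, as 2-fluorophenyl leaves a 4.5-fold higher number from compound 1 to compound 4 (0.66 log units; beyond the scatter), yet the phenyl rings are not equivalent, since replacing 3-fluoro-4-hydroxyphenyl gives a 3.1-fold lower number from compound 2 to compound 4 (0.50 log units; beyond the scatter). Leaving thiophen-2-yl gives an at least 3.2-fold lower number from compound 3 to compound 4 (0.50 log units; beyond the scatter), which is only a floor. Compound 3 is reported only as a limit: the limit of > 100000 nM in this assay, at which 1 of the 4 values shown sits.

Going by these compounds, it remains open whether the halogen or its place on the ring separates 4-chlorophenyl from 2-fluorophenyl, as the two differ in both. On these data alone, how 4-fluorophenyl, or a phenyl ring bearing an amine or a carboxylic acid, would behave at this carbon also remains open.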